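Working notes: sulfonyl group change at compound 3

A few compounds are considered here, and "the series" means these few. Any claim that something is new, unique, unknown or untested is made for them only; others in the source may bear on it.

compound 1 `COc1ccc([C@H]2CC(=O)N(c3ccccc3)C2)cc1OC1CCCC1`: > 10000 nM (limit)
compound 2 `COc1ccc([C@H]2CC(=O)N(c3cccc(NS(=O)(=O)c4ccccc4F)c3)C2)cc1OC1CCCC1`: > 10000 nM (limit)

In a functional assay on HEK293 cells (Homo sapiens) for cytotoxicity (a lower number here means that less compound is tolerated, a higher number that more compound is tolerated), compound 2 stands at > 10000 nM, which is a limit and not a number. Compound 1 gives > 10000 nM, also a limit. The whole picture so far is the limit of > 10000 nM in this assay, at which 2 of the 2 values shown sit.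

Compound 3 `COc1ccc([C@H]2CC(=O)N(c3cccc(NS(=O)(=O)c4cc(Br)c(Cl)s4)c3)C2)cc1OC1CCCC1` carries 4-bromo-5-chlorothiophen-2-yl in place of 2-fluorophenyl on a sulfonyl sulfur.

For the measured compounds named here, the only measured step is a step that the two limits leave unreadable from compound 1 to compound 2. Going by the values given here, it offers no size to carry over, and no measured step changes the group on the sulfonyl sulfur. Compound 2 rests at > 10000 nM, a limit, so no step beyond the scatter is expected in this assay. The estimated change is a step that the limit leaves unreadable from compound 2 to compound 3. For compound 3 the expected value is 15000 nM, with an estimated range of 6000 nM to 50000 nM.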

Compound 3, half-maximal cytotoxic concentration: > 10000 nM
Compound 3 ended at the assay's limit (the forecaster's own chance of this, stated with the estimate: 75%); the middle value is on the limit's open side.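

No step can be read among compound 1, compound 2 and compound 3, because all three values are limits and not numbers: the limit of > 10000 nM in this assay, at which 3 of the 3 values shown sit.

From the compounds shown here alone, whether the group on the sulfonyl sulfur changes the tolerated concentration in this assay stays open, as does the true value of each compound.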